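The compounds below may be only part of what the source reports. "The series", "measured", "known", "first", "only" and "open" are said of these compounds alone.

Of the compounds shown here, two with a shared core have been measured in a functional assay on HEK293 cells for antagonist activity at proteinase-activated receptor 4 (Homo sapiens), read by FLIPR and calcium flux, with a stated time of 30 min; on this read-out higher numbers stand for weaker inhibition and lower numbers for stronger inhibition. Compound 1 `CS(=O)(=O)c1nn2cc(-c3cc4ccccc4o3)nc2s1` carries a methylsulfonyl group on an aromatic carbon, and in this assay compound 1 gives 820 nM. Compound 2 `CCOc1nn2cc(-c3cc4ccccc4o3)nc2s1` carries an ethoxy group in that place, and in this assay compound 2 gives 67 nM. This single exchange brought a 12-fold lower number from compound 1 to compound 2 (1.09 log units; beyond the scatter), which marks compound 2 as the lower of the two numbers shown, with compound 1 as its only neighbour.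

Compound 3 `CC(C)Oc1nn2cc(-c3cc4ccccc4o3)nc2s1` differs from compound 2 by methyl in place of hydrogen on a saturated chain carbon bound to an oxygen on an aromatic ring and a saturated chain carbon. Among the measured compounds shown here, no measured step covers exactly this kind of change: the one step available shows that the group on this aromatic carbon matters greatly, but it swaps a whole group rather than lengthening a chain by one methyl. Lengthening alone would usually be expected to move the number by little. For compound 3 the number in this assay is therefore estimated at 60 nM, within a range from 20 nM to 200 nM. This estimate means a step of a 1.1-fold lower number from compound 2 to compound 3 (0.05 log units; within the scatter), within the scatter.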

Compound 3, half-maximal inhibitory concentration: 760 nM
Compound 3: middle estimate off by 13-fold (1.10 log units), on the low side; measured number outside the range, above it.
By their numbers in this assay, from the lowest: compound 2; then compounds 3 and 1 (each within the scatter of the next).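

In this assay this position proves highly sensitive to a very small change: adding one methyl on the saturated chain carbon bound to the oxygen, which turns ethoxy into isopropoxy, gives an 11-fold higher number from compound 2 to compound 3 (1.05 log units; beyond the scatter) in the direction of weaker inhibition. The earlier pair alone could have suggested that an oxygen-linked chain in this place is enough for a low number, but compound 3 carries such a chain and goes against that reading. Exchanging the whole group gives a 1.1-fold lower number from compound 1 to compound 3 (0.03 log units; within the scatter) and so leaves isopropoxy and methylsulfonyl indistinguishable here, which means that among these three compounds only the ethoxy group of compound 2 gives the low number, and the exact shape of the chain counts, not just the oxygen.

On these data alone, it remains open whether the loss follows the branch at that carbon or simply the added carbon, and a straight propoxy chain or a shorter methoxy group in the same place would help to separate the two. Nothing available here accounts for why a single methyl produces a step of this size.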